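Swapping an acid chain for a methyl ester

The compounds below may be only part of what the source reports. "The series", "measured", "known", "first", "only" and "open" are said of these compounds alone.

- compound 1 `CC1=C(C)C(=O)C(C(CCCCCCC(=O)O)c2ccccc2)=C(C)C1=O` gives 3200 nM
- compound 2 `CC1=C(C)C(=O)C(C(CCCCCCCC(=O)O)c2ccccc2)=C(C)C1=O` gives 3400 nM
- compound 3 `CC1=C(C)C(=O)C(C(CCCCCC(=O)O)c2ccccc2C)=C(C)C1=O` gives 3200 nM

All three were tested in a functional assay (aorta) with Oryctolagus cuniculus as the target (a lower number here means a stronger inhibitor, a higher number a weaker inhibitor), and lie within the scatter of one another, so compound 2 stands level with the other two. Compound 4 `COC(=O)CCCCCC(C1=C(C)C(=O)C(C)=C(C)C1=O)c1ccccc1` carries methoxycarbonyl in place of 2-carboxyethyl on a saturated chain carbon, six bonds along the chain from an aromatic carbon and a double-bonded ring carbon and is not yet measured. Among the compounds with values here, the only measured step that bears on this is a 1.1-fold higher number from compound 1 to compound 2 (0.03 log units; within the scatter) and it concerns the chain alone. Within the data shown here, no measured compound carries methoxycarbonyl, so that part of the change is untested. A small expected step toward a weaker number is a 1.8-fold higher number from compound 2 to compound 4 (0.25 log units; within the scatter) and it remains uncertain. Expected for compound 4 is 6000 nM within an estimated range from 1800 nM to 20000 nM.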

Compound 4, half-maximal inhibitory concentration: 1400 nM
Compound 4: middle estimate off by 4.3-fold (0.63 log units), on the high side; the measured number lies below the stated range.
By their numbers in this assay, from the lowest: compound 4; then compounds 1, 3 and 2 (each within the scatter of the next).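

In this assay, changing the end of this chain moves the number beyond the scatter, which the step between the two acids did not do: replacing 2-carboxyethyl with methoxycarbonyl gives a 2.4-fold lower number from compound 2 to compound 4 (0.39 log units; beyond the scatter), and replacing carboxymethyl with methoxycarbonyl gives a 2.3-fold lower number from compound 1 to compound 4 (0.36 log units; beyond the scatter). So a methyl ester at this position goes with a modestly stronger inhibitor than either acid it is compared with here. Nothing measured here gives a reason for this shift.

Going by these compounds, each step changes the chain end and the chain length together, so their separate shares stay open. Also open, on these data alone, is whether an ethyl ester or a primary amide at the chain end would keep the lower number.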